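The compounds below may be only part of what the source reports. "The series", "measured", "known", "first", "only" and "open" are said of these compounds alone.

Of the compounds shown here, three from this study have been tested in a functional assay on 3T3-L1 cells (Mus musculus) for inhibition, with a stated time of 20 min, tested at 20 uM; on this read-out higher numbers stand for more inhibition at the one concentration tested (going by the name of the read-out) and lower numbers for less inhibition. Compound 1 `Cc1ccc(S(=O)(=O)n2cc(CN(Cc3cn(Cc4ccc(F)cc4)nn3)S(C)(=O)=O)c3ccccc32)cc1` gives -19.5% there, compound 3 `Cc1ccc(S(=O)(=O)n2cc(CN(Cc3cn(Cc4ccc(F)cc4)nn3)S(=O)(=O)c3ccccc3)c3ccccc32)cc1` gives -21%, and compound 2 `Cc1ccc(S(=O)(=O)N(Cc2cn(Cc3cc(F)ccc3F)nn2)Cc2cn(S(C)(=O)=O)c3ccccc23)cc1` gives 3.4%. Compound 3 is made from compound 1 by a single change, (phenyl in place of methyl on a sulfonyl sulfur), and that change moves this assay by a number 1.5 percentage points lower from compound 1 to compound 3 (within the scatter). Compound 2 stands highest of the three, with compound 1 nearest to it and compound 3 furthest; the difference between the core of compound 2 and the core of compound 1 is not broken down here.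

Compound 4 `Cc1ccc(S(=O)(=O)N(Cc2cn(Cc3cc(F)ccc3F)nn2)Cc2cn(S(=O)(=O)c3ccccc3)c3ccccc23)cc1` has not yet been measured. Among the compounds with values here, it is made from compound 2 by phenyl in place of methyl on a sulfonyl sulfur, the same kind of change as the one from compound 1 to compound 3, though not the same: in compound 1 the sulfonyl sulfur's other neighbour is a sulfonamide nitrogen, in compound 2 it is an aromatic nitrogen. Because the earlier step was a number 1.5 percentage points lower from compound 1 to compound 3 (within the scatter), the step from compound 2 to compound 4 is expected to be small as well, near a number 1.4 percentage points lower from compound 2 to compound 4 (within the scatter). Compound 4 is therefore estimated at 2%, within a range from -12% to 16%.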

Compound 4, a percentage reported as inhibition, at one concentration (the size of the read-out at that concentration, not a potency): -6.5%
The estimate for compound 4 lay 8.5 percentage points above the measured number, within the range that was stated.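

In this assay, phenyl in place of methyl on a sulfonyl sulfur whose other neighbour is an aromatic nitrogen comes out as a number 9.9 percentage points lower from compound 2 to compound 4 (within the scatter). Set beside the earlier step, the change does not separate the two cores: the same change on two cores in this assay, a number 1.5 percentage points lower (within the scatter) from compound 1 to compound 3 and a number 9.9 percentage points lower (within the scatter) from compound 2 to compound 4, 8.4 percentage points apart, within the scatter of two such steps

So, as far as these two pairs can tell, the change carries from one core to the other without a difference that rises above the scatter, but this does not prove that its size is the same on both cores, and it says nothing about any further core.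

The compounds shown leave open how other groups on that sulfonyl sulfur, such as an ethyl chain, a longer alkyl chain or an amine, would read out on either core. From the compounds shown here alone, it also remains open whether the same picture would hold at any concentration other than the single one tested.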